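The source may report more compounds than this note shows. Statements on the series, on what has been measured and on what is new or still open speak of the compounds shown alone.

Measured in a functional assay on DU-145 cells (Homo sapiens) for antiproliferative activity, read by MTT assay, with a stated time of 48 h; on this read-out higher numbers stand for weaker inhibition and lower numbers for stronger inhibition:
- compound 1 `C/C(=C\CC/C(C)=C/CC[C@@H]1[C@@]2(C)CCC(=O)C(C)(C)[C@H]2CC[C@@]1(C)O)CC/C=C(\C)C(=O)OCc1cn(-c2ccccc2[N+](=O)[O-])nn1`: > 150000 nM (a limit)
- compound 2 `C#CCOC(=O)/C(C)=C/CC/C(C)=C/CC/C(C)=C/CC[C@@H]1[C@@]2(C)CCC(=O)C(C)(C)[C@H]2CC[C@@]1(C)O`: 46100 nM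
- compound 3 `C/C(=C\CC/C(C)=C/CC[C@@H]1[C@@]2(C)CCC(=O)C(C)(C)[C@H]2CC[C@@]1(C)O)CC/C=C(\C)C(=O)OCc1cn(-c2ccc(Br)cc2)nn1`: > 150000 nM (a limit)

Compound 3 has no number, only the limit > 150000 nM. Compound 4 `C/C(=C\CC/C(C)=C/CC[C@@H]1[C@@]2(C)CCC(=O)C(C)(C)[C@H]2CC[C@@]1(C)O)CC/C=C(\C)C(=O)OCc1cn(-c2ccccc2Cl)nn1` carries 2-chlorophenyl in place of 4-bromophenyl on an aromatic nitrogen. The closest measured change, on the same aromatic nitrogen, is a step that the two limits leave unreadable from compound 1 to compound 3. The other measured change, an at least 3.2-fold higher number from compound 2 to compound 3 (0.51 log units; beyond the scatter), replaces ethynyl with the 1-(4-bromophenyl)-1H-1,2,3-triazol-4-yl group. Both compounds with an aryl on that nitrogen sit at the limit of > 150000 nM in this assay, at which 2 of the 3 values shown sit, so no step beyond the scatter is expected in this assay, and no direction can be given. The step expected is a step that the limit leaves unreadable from compound 3 to compound 4. The estimate for compound 4 is 160000 nM, with an expected range of 70000 nM to 300000 nM.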

Compound 4, half-maximal inhibitory concentration: > 150000 nM
Compound 4 gave a limit, no number; the forecaster's own chance of this, stated with the estimate: 75%; the middle value is on the limit's open side.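

In this assay compound 4 gives only a limit, > 150000 nM. With 2-chlorophenyl on the aromatic nitrogen, the triazole ester still stands apart from the ethynyl compound, with an at least 3.2-fold higher number from compound 2 to compound 4 (0.51 log units; beyond the scatter), so this separation now holds for a chloro-substituted aryl as well as the bromo-substituted one. The steps among compound 1, compound 3 and compound 4 cannot be read, so no ranking of these aryl groups is possible: the limit of > 150000 nM in this assay, at which 3 of the 4 values shown sit.

Still open, from the compounds shown here alone, is whether an aminophenyl group, a carboxylic acid on the phenyl ring or a plain butyl chain on that nitrogen would give a measurable value.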